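Bromo for Nitro on a Potent Dihydropyran Growth Inhibitor

The source may report more compounds than this note shows. Statements on the series, on what has been measured and on what is new or still open speak of the compounds shown alone.

Measured compounds:
Compound 1 `N#CCC1=NN=C(c2ccc(Br)cc2)C(CC(=O)c2ccc(Br)cc2)O1` gives 30400 nM in a functional assay on MCF7 cells (Homo sapiens) for inhibition, read by sulforhodamine B assay, with a stated time of 48 h; on this read-out lower numbers stand for stronger inhibition of growth and higher numbers for weaker inhibition of growth.
Compound 2 `N#CCC1=C(C#N)CC(c2ccc([N+](=O)[O-])cc2)=C(CC(=O)c2ccc([N+](=O)[O-])cc2)O1` gives 30 nM in this assay.
Compound 3 `N#CCC1=NN=C(c2ccc([N+](=O)[O-])cc2)C(CC(=O)c2ccc(Br)cc2)O1` gives 36000 nM in this assay.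

Compound 2 stands apart: its numbers against compound 1 and compound 3 show gaps far beyond the scatter. The core of compound 2 differs from that of compound 3 in a way that is not broken down here.

From compound 3 to compound 1 the change is bromo in place of nitro on an aromatic carbon, and it made a step of a 1.2-fold lower number from compound 3 to compound 1 (0.07 log units; within the scatter). Compound 4 `N#CCC1=C(C#N)CC(c2ccc(Br)cc2)=C(CC(=O)c2ccc([N+](=O)[O-])cc2)O1` carries the same change against compound 2, (bromo in place of nitro on an aromatic carbon), at the same place. Because the earlier step of a 1.2-fold lower number from compound 3 to compound 1 (0.07 log units; within the scatter) stayed within the scatter, a similarly small step is expected here, a 1.2-fold higher number from compound 2 to compound 4 (0.07 log units; within the scatter), though the core is different. Compound 4 is estimated at 35 nM, between 8 nM and 150 nM.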

Compound 4, concentration for 50% growth inhibition: 90 nM
Beside the measured number, compound 4's estimate is 2.6-fold (0.41 log units) below it; low and high end bracket the measured number.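

On the core of compound 2, replacing nitro with bromo weakens growth inhibition in this assay, with a 3.0-fold higher number from compound 2 to compound 4 (0.48 log units; beyond the scatter). The size of the step therefore did not carry over from one core to the other: the same change on two cores in this assay, a 1.2-fold lower number (0.07 log units; within the scatter) from compound 3 to compound 1 and a 3.0-fold higher number (0.48 log units; beyond the scatter) from compound 2 to compound 4, 3.6-fold (0.55 log units) apart, beyond the scatter of two such steps

This shows that a small step on one core is no safe guide to the step on another, but it rests on a single pair of compounds per core and does not show why the two steps differ. From the compounds shown here alone, it remains open whether other groups in the same place, such as an amine or a carboxylic acid, would also give different steps on the two cores. Going by these compounds, it also remains open whether a second pair on each core would repeat this gap.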